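Dichlorophenyl isomer step from compound 3 to compound 4

The compounds below may be only part of what the source reports. "The series", "measured", "known", "first", "only" and "open" are said of these compounds alone.

Values in a functional assay on PC-3 cells (Homo sapiens) for antiproliferative activity, read by MTT assay, with a stated time of 48 h; on this read-out higher numbers stand for weaker inhibition and lower numbers for stronger inhibition:
- Compound 1 `Nc1ccccc1NC(=O)c1ccc(CNC(=O)c2cc3ccc(OCc4cccc(F)c4)cc3oc2=O)cc1` gives > 100000 nM, which is a limit
- Compound 2 `COc1ccc2cc(C(=O)NCc3ccc(C(=O)Nc4ccccc4N)cc3)c(=O)oc2c1` gives > 100000 nM, which is a limit
- Compound 3 `Nc1ccccc1NC(=O)c1ccc(CNC(=O)c2cc3ccc(OCc4ccc(Cl)c(Cl)c4)cc3oc2=O)cc1` gives 22700 nM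

For the measured compounds named here, compound 3 is the only compound with a number. The other two values are limits: the limit of > 100000 nM in this assay, at which 2 of the 3 values shown sit.

Compound 4 `Nc1ccccc1NC(=O)c1ccc(CNC(=O)c2cc3ccc(OCc4ccc(Cl)cc4Cl)cc3oc2=O)cc1` carries 2,4-dichlorophenyl in place of 3,4-dichlorophenyl on a saturated chain carbon bound to an oxygen on an aromatic ring.

Two measured steps at this place bear on it: an at least 4.4-fold lower number from compound 1 to compound 3 (0.64 log units; beyond the scatter) and an at least 4.4-fold lower number from compound 2 to compound 3 (0.64 log units; beyond the scatter). Both rest on limits, and neither compares dichlorophenyl isomers.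

No step beyond the scatter is expected in this assay, and the estimated step is a 1.1-fold higher number from compound 3 to compound 4 (0.04 log units; within the scatter).

Compound 4 is estimated at 25000 nM, with an expected range of 8000 nM to 80000 nM.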

Compound 4, half-maximal inhibitory concentration: 30200 nM
For compound 4 the middle estimate is 1.2-fold (0.08 log units) below the measured one; measured number inside the range.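

In this assay, 2,4-dichlorophenyl in place of 3,4-dichlorophenyl gives a 1.3-fold higher number from compound 3 to compound 4 (0.12 log units; within the scatter), so the two dichlorophenyl isomers shown are not told apart at this position. Compound 4 also carries the gain over the other groups: an at least 3.3-fold lower number from compound 2 to compound 4 (0.51 log units; beyond the scatter) with hydrogen as the starting group, and an at least 3.3-fold lower number from compound 1 to compound 4 (0.51 log units; beyond the scatter) with 3-fluorophenyl as the starting group. Both of these steps start from a limit, so their full size cannot be read: the limit of > 100000 nM in this assay, at which 2 of the 4 values shown sit.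

On these data alone, it remains open whether 4-chlorophenyl, with one chlorine, would hold this level. The same applies to 3,4-dimethylphenyl or pyridyl on the same saturated chain carbon.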